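This account rests on a few compounds, and the source may have more. Where it says the series, first, only, none or still open, it means among the compounds named here.

Compound 1 `C[C@H](NC(=O)c1c(Cc2ccc(C(C)(C)C)cc2)sc2c1CCOC2)c1ccc(C(=O)O)cc1` is the reference point here. In a functional assay on CHO/Galpha16 cells for antagonist activity at prostaglandin E2 receptor EP4 subtype (Homo sapiens), read by calcium flux, with a stated time of 15 min (a higher number here means a weaker inhibitor, a lower number a stronger inhibitor), compound 1 gives 9.5 nM, the lower of the two numbers that were obtained, and the gap to the nearest of them lies beyond the usual scatter. That nearest measured neighbour is compound 3 `O=C(NCC1CCC(C(=O)O)CC1)c1c(Cc2ccc(F)cc2)sc2c1CCOC2`, which in this assay gives 30.3 nM. Compound 2 `CC(=O)N1CCc2c(sc(CCc3ccc(F)cc3)c2C(=O)N[C@@H](C)c2ccc(C(=O)O)cc2)C1` is reported in this assay only as a limit of the assay, > 1000 nM; the same limit appears in the limit of > 1000 nM in this assay, at which 1 of the 3 values shown sits.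

The step under consideration leads to compound 4 `C[C@H](NC(=O)c1c(Cc2cccc(F)c2)sc2c1CCOC2)c1ccc(C(=O)O)cc1`, which differs from compound 1 only by 3-fluorophenyl in place of 4-(tert-butyl)phenyl on a saturated chain carbon bound to an aromatic carbon. No single-change comparison among the measured compounds covers this exchange. The step from compound 1 to compound 4 is expected to be a moderate loss, a 6.3-fold higher number from compound 1 to compound 4 (0.80 log units; beyond the scatter), beyond the scatter. Compound 4 is estimated at 60 nM in this assay, within a range from 15 nM to 250 nM.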

Compound 4, half-maximal inhibitory concentration: 5.1 nM
Compound 4: the middle estimate sits 12-fold (1.07 log units) above what was measured; measured number below the stated range.
By their numbers in this assay, from the lowest: compounds 4 and 1 (each within the scatter of the next); then compound 3. At a limit, above all of these: compound 2.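

In this assay, 3-fluorophenyl in place of 4-(tert-butyl)phenyl on a saturated chain carbon bound to an aromatic carbon gives a 1.9-fold lower number from compound 1 to compound 4 (0.27 log units; within the scatter), so this place accepts the exchange with the rest of compound 1 unchanged. In this one pair, 3-fluorophenyl stands level with 4-(tert-butyl)phenyl, the group with more heavy atoms, although the exchange alters the substituent and its ring position together, and the pair cannot separate the two. The data shown offer nothing that bears on why the two numbers lie so close.

On these data alone, it remains open what an unsubstituted phenyl, a methoxy group or an amine on this ring would give with the same core and side chain. Also open, as far as these compounds go, is whether a pyridine ring could stand in place of the benzene ring here.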